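Outlook for compound 4 in the aryl-sulfonamide series

The source may hold more compounds than are shown below. What is called first, only, known or untested is meant among the compounds shown, and "the series" means these compounds.

Measured so far:
compound 1 `CCCCCNc1cccc2c(S(=O)(=O)Nc3onc(C)c3C)cccc12` — 80 nM
compound 2 `Cc1noc(NS(=O)(=O)c2cccc3c(CN(C)C)cccc23)c1C` — 2800 nM
compound 3 `Cc1noc(NS(=O)(=O)c2cccc3c(NCc4ccccc4)cccc23)c1C` — 590 nM

In an assay on VSM-A10 cells for antagonist activity at Endothelin-1 receptor (Rattus norvegicus) (a higher number here means a weaker inhibitor, a lower number a stronger inhibitor), compound 3 gives the second highest of the three numbers. Its nearest neighbour is compound 2, separated by a 4.7-fold lower number from compound 2 to compound 3 (0.68 log units; beyond the scatter); the furthest is compound 1, separated by a 7.4-fold higher number from compound 1 to compound 3 (0.87 log units; beyond the scatter).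

Compound 4 `Cc1noc(NS(=O)(=O)c2cccc3c(N4CCCC4=O)cccc23)c1C` is not yet measured in this assay. The change from compound 3 is 2-oxopyrrolidin-1-yl in place of benzylamino on an aromatic carbon. The entering group has no hydrogen-bond donor and one acceptor; the leaving benzylamino carries one donor and one acceptor.

Two measured steps exchange the group at this same aromatic carbon and therefore bear on the change: a 35-fold higher number from compound 1 to compound 2 (1.54 log units; beyond the scatter) and a 4.7-fold lower number from compound 2 to compound 3 (0.68 log units; beyond the scatter). Within the data shown here, both are beyond the scatter, and the only group so far without a donor, in compound 2, gives the highest number. A modest rise in this assay from compound 3 to compound 4 is therefore expected, though the new group matches none of the earlier ones closely and the range is set wide.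

For compound 4 the estimate is 1800 nM, with a range from 500 nM to 6000 nM, which amounts to an expected 3.1-fold higher number from compound 3 to compound 4 (0.48 log units; beyond the scatter).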

Compound 4, half-maximal inhibitory concentration: 130 nM
Compound 4: the middle estimate sits 14-fold (1.14 log units) above what was measured; measured number outside the range, below it.
By their numbers in this assay, from the lowest: compounds 1 and 4 (each within the scatter of the next); then compound 3; then compound 2.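

In this assay, a hydrogen-bond donor on this aromatic carbon proves dispensable: 2-oxopyrrolidin-1-yl, with 0 hydrogen-bond donors, gives a 4.5-fold lower number from compound 3 to compound 4 (0.66 log units; beyond the scatter) and a 22-fold lower number from compound 2 to compound 4 (1.33 log units; beyond the scatter) as well. It also stands level with the donor-bearing pentylamino group, with a 1.6-fold higher number from compound 1 to compound 4 (0.21 log units; within the scatter), so donor count does not order these compounds, and compound 2 and compound 4, both without a donor, lie at far apart values. Among the compounds shown, the three with a nitrogen bound directly to the aromatic carbon all give lower numbers than compound 2, whose group is attached through a carbon, but this rests on a single such compound, and no measurement here explains the result.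

Still open, from the compounds shown here alone, is whether the carbonyl or the ring of 2-oxopyrrolidin-1-yl carries the result, which a plain pyrrolidin-1-yl group and an open-chain acetamide on the same carbon would separate. A dimethylamino group placed directly on the aromatic carbon would likewise show whether the high number of compound 2 goes with its carbon link or with its tertiary amine.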